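Replacing 2-Bromophenyl with Benzoyl at the Sulfur Chain

A few compounds are considered here, and "the series" means these few. Any claim that something is new, unique, unknown or untested is made for them only; others in the source may bear on it.

Compound 1 `Cc1cc(Nc2cc(-c3ccccc3)[nH]n2)n2nc(SCc3csc4ccccc34)nc2n1`: 29200 nM
Compound 2 `Cc1cc(Nc2cc(-c3ccccc3)[nH]n2)n2nc(SCc3cccc(Br)c3)nc2n1`: > 50000 nM, a limit of the assay rather than a number
Compound 3 `Cc1cc(Nc2cc(-c3ccccc3)[nH]n2)n2nc(SCc3ccccc3Br)nc2n1`: 41100 nM

The three measured compounds share one core and differ only in the group on a saturated chain carbon bound to a sulfur. In an ADME assay on GES1 cells (Homo sapiens) for inhibition, read by MTT assay, with a stated time of 72 h (on this read-out lower numbers stand for stronger inhibition and higher numbers for weaker inhibition), compound 1 gives 29200 nM. Compound 2 reaches only the limit of this assay, > 50000 nM, and so has no number. Compound 3 gives 41100 nM, the higher of the two numbers available, yet the step of a 1.4-fold higher number from compound 1 to compound 3 (0.15 log units; within the scatter) stays within the scatter. The other two steps, an at least 1.7-fold higher number from compound 1 to compound 2 (0.23 log units; that floor lies within the scatter) and an at least 1.2-fold lower number from compound 2 to compound 3 (0.08 log units; that floor lies within the scatter), also stay within the scatter, so swapping groups at this place has so far not shifted the read-out beyond noise.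

Compound 4 `Cc1cc(Nc2cc(-c3ccccc3)[nH]n2)n2nc(SCC(=O)c3ccccc3)nc2n1` has not been measured. It differs from compound 3 in one place: benzoyl in place of 2-bromophenyl on a saturated chain carbon bound to a sulfur. Within the data shown here, no measured step introduces a benzoyl here, so only the three within-scatter steps at the same place guide the expectation. On that basis the expected step is a 1.0-fold lower number from compound 3 to compound 4 (0.01 log units; within the scatter), nothing beyond the scatter. Compound 4 is therefore expected to give about 40000 nM, between 18000 nM and 90000 nM, with a real chance that this assay again reports only a limit.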

Compound 4, half-maximal inhibitory concentration: 33300 nM
For compound 4 the middle estimate is 1.2-fold (0.08 log units) above the measured one, and the stated range covers the measured number.
By their numbers in this assay, from the lowest: compounds 1, 4 and 3 (each within the scatter of the next). At a limit, above all of these: compound 2.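

Unlike 2-bromophenyl, benzoyl carries a carbonyl with a hydrogen-bond acceptor and no bromine, yet in this assay this change gives a 1.2-fold lower number from compound 3 to compound 4 (0.09 log units; within the scatter). Setting benzoyl in place of 1-benzothiophen-3-yl gives a 1.1-fold higher number from compound 1 to compound 4 (0.06 log units; within the scatter), so a group of a different kind from the aryl groups seen so far on this saturated chain carbon bound to a sulfur still leaves the read-out within the scatter. The comparison with the 3-bromophenyl compound gives an at least 1.5-fold lower number from compound 2 to compound 4 (0.17 log units; that floor lies within the scatter), and this is only a floor, because that compound has a limit of the assay rather than a number, so the true size of the step stays unknown: the limit of > 50000 nM in this assay, at which 1 of the 4 values shown sits.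

The compounds shown leave open whether any group at this place can move the read-out beyond the scatter, for example an amine, a carboxylic acid or a longer chain in place of benzoyl. They also leave open whether changes elsewhere would matter, since all four compounds share the same core and differ only at this one place.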